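Amide substituent change in the shared core series

A few compounds are considered here, and "the series" means these few. Any claim that something is new, unique, unknown or untested is made for them only; others in the source may bear on it.

Compound 2 `CCN(CC)C(=O)CCSc1nc2cc(Cl)ccc2o1` and compound 1 `COc1ccc2oc(SCCC(=O)N3CCCC3)nc2c1` share a core and differ both in the amide group and in the substituent on the aromatic part. In an ADME assay on microsomes from liver (Homo sapiens) for metabolic stability, read by LC-MS, using NADPH, with a stated time of 45 min, tested at 0.5 uM (on this read-out lower numbers stand for slow clearance and higher numbers for fast clearance), compound 2 gives 5.9 mL/min/g, and in this assay compound 1 gives 6.1 mL/min/g; the two values lie within the scatter of each other, so neither compound is set apart by this read-out. Compound 3 `CC1CCCN1C(=O)CCSc1nc2cc(Cl)ccc2o1` is the next member; relative to compound 2 it carries 2-methylpyrrolidin-1-yl in place of diethylamino on a carbonyl carbon. For the measured compounds named here, no measured pair isolates this change, and the two measured compounds differ in two places, so the data do not show how the amide group alone acts on this read-out. For compound 3 the expected step is a 1.0-fold higher number from compound 2 to compound 3 (0.01 log units; within the scatter), a change not beyond the scatter. In this assay compound 3 is estimated at 6 mL/min/g, within a range from 3.5 mL/min/g to 10 mL/min/g.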

Compound 3, intrinsic clearance in a liver preparation (reported as CLH), per the amount of preparation that the assay uses: 8.5 mL/min/g
The estimate for compound 3 lay 1.4-fold (0.15 log units) below the measured number, and the stated range covers the measured number.
By their numbers in this assay, from the lowest: compounds 2, 1 and 3 (each within the scatter of the next).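

The series now holds its first pair that differs in one place, so the amide group can be read alone: in this assay, 2-methylpyrrolidin-1-yl in place of diethylamino on a carbonyl carbon gives a 1.4-fold higher number from compound 2 to compound 3 (0.16 log units; within the scatter) on this read-out. Swapping the open diethylamino for a group with a five-membered non-aromatic ring therefore does not set the two amides apart here. Nothing at hand bears on the reason for this result.

Still open, from the compounds shown here alone, is what the methyl on the ring contributes on its own, and how the substituent on the aromatic part acts when the amide group is held fixed. A plain pyrrolidin-1-yl or a morpholin-4-yl amide on the chlorine-bearing core would show whether this position stays as undiscriminating with other amines.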